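The source may report more compounds than this note shows. Statements on the series, on what has been measured and on what is new or still open speak of the compounds shown alone.

Values in an ADME assay on BJ cells (Homo sapiens) for cytotoxicity, with a stated time of 72 h (on this read-out higher numbers stand for an effect only at larger amounts of compound and lower numbers for an effect already at smaller amounts), each of them a limit:
Compound 1 `CCc1ccc(-c2nc3c(c(C)nn3-c3ccccc3)c(-c3ccccc3[N+](=O)[O-])c2C#N)cc1`: > 20000 nM
Compound 2 `CCc1ccc(-c2nc3c(c(C)nn3-c3ccccc3)c(-c3ccccc3)c2C#N)cc1`: > 20000 nM
Compound 3 `CCc1ccc(-c2nc3c(c(C)nn3-c3ccccc3)c(-c3ccccc3C(=O)OC)c2C#N)cc1`: > 20000 nM

Compound 3 shares (the limit of > 20000 nM in this assay, at which 3 of the 3 values shown sit). Compound 4 `C#Cc1ccccc1-c1c(C#N)c(-c2ccc(CC)cc2)nc2c1c(C)nn2-c1ccccc1` carries ethynyl in place of methoxycarbonyl on an aromatic carbon, ortho to a large group: ethynyl in place of methoxycarbonyl on an aromatic carbon. Three measured changes bear on this one: a step that the two limits leave unreadable from compound 1 to compound 2, a step that the two limits leave unreadable from compound 1 to compound 3 and a step that the two limits leave unreadable from compound 2 to compound 3. None of them has a readable size, so they offer no sign of a real effect from such a swap. No step beyond the usual scatter is therefore expected in this assay, and another limit is the likeliest result. The expected change is a number no higher from compound 3 to compound 4 (the limit leaves the size open). For compound 4 the estimate is 20000 nM, with an expected range of 10000 nM to 40000 nM.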

Compound 4, half-maximal effective concentration in the BJ assay: > 20000 nM
Compound 4: only a limit was reported (the forecaster's own chance of this, stated with the estimate: 85%); the middle value sits exactly at the limit.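

In the BJ assay compound 4 gives > 20000 nM, which is a limit. For the compounds shown here, compound 1, compound 2 and compound 3 also give only limits in the BJ assay, so no step between them can be read. From the compounds shown here alone, the amount at which any of them would show an effect stays open. In a physicochemical assay for solubility, read by spectrophotometry, in phosphate buffer, with a stated time of 18 h, at pH 7.4 (on this read-out lower numbers stand for lower solubility and higher numbers for higher solubility), compound 3 gives 17000 nM and compound 4 gives 46000 nM.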